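The compounds below may be only part of what the source reports. "The series", "measured", "known", "first", "only" and "open" are said of these compounds alone.

For the measured compounds named here, in an ADME assay on a cell-free system (plasma, Homo sapiens) for metabolic stability, with a stated time of 90 min (a higher number here means that more of the compound is left, a lower number that less of the compound is left), compound 1 (`COCC(=O)NCCCCCC(=O)N[C@H](C(=O)N1C[C@H](O)C[C@H]1C(=O)NCc1ccc(-c2scnc2C)cc1)C(C)(C)C`) gives 126%, the higher of the two numbers measured so far. Compound 2 (`Cc1ncsc1-c1ccc(CNC(=O)[C@@H]2C[C@@H](O)CN2C(=O)[C@@H](NC(=O)CCCCCOC(=O)CC(c2ccccc2)c2ccccc2)C(C)(C)C)cc1`) gives 58%, lower by a margin beyond the usual scatter. Compound 3 (`Cc1ncsc1-c1ccc(CNC(=O)[C@@H]2C[C@@H](O)CN2C(=O)[C@@H](NC(=O)CCCCCOC(=O)C2CCCCC2)C(C)(C)C)cc1`) has not yet been measured in this assay. Its structure departs from that of compound 1 in one place: (cyclohexylcarbonyl)oxy in place of ((methoxymethyl)carbonyl)amino on a saturated chain carbon, five bonds along the chain from a carbonyl carbon. The new group, (cyclohexylcarbonyl)oxy, stands in place of ((methoxymethyl)carbonyl)amino on a saturated chain carbon, five bonds along the chain from a carbonyl carbon. Going by the values given here, no measured pair of compounds isolates a change of this kind, so the expectation rests on thin evidence. Compound 2 also carries a carbonyl-oxy link on a saturated chain carbon, five bonds along the chain from a carbonyl carbon, and it gives 58%. A clear fall is therefore expected, close to the gap seen between the two measured compounds. The expected change is a number 71 percentage points lower from compound 1 to compound 3 (beyond the scatter). For compound 3 the estimated value is 55%. The estimated range for compound 3 runs from 25% to 85%.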

Compound 3, percent of the compound remaining: 14%
Compound 3: middle estimate off by 41 percentage points, on the high side; measured number outside the range, below it.
By their numbers in this assay, from the lowest: compound 3; then compound 2; then compound 1.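

this assay now has its first step that changes only this place, the saturated chain carbon five bonds along the chain from a carbonyl carbon: (cyclohexylcarbonyl)oxy in place of ((methoxymethyl)carbonyl)amino gives a number 112 percentage points lower from compound 1 to compound 3 (beyond the scatter). The read-out at this place therefore depends strongly on the group it carries, with the rest of the structure held the same as in the core of compound 1. The change has several parts: it replaces the amino link with an oxy link, goes from 1 hydrogen-bond donor to 0, and brings in a six-membered non-aromatic ring of carbon only, while no measurement at hand gives a reason for the fall.

The compounds shown leave open whether the fall follows the oxy link, the cyclohexyl ring or the two together, as all of these change in the one step. A (cyclohexylcarbonyl)amino group at this place would keep the ring and restore the amino link, and a ((methoxymethyl)carbonyl)oxy group would do the reverse, so these two groups would separate the parts of the change.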